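Chloro Substitution on the Urea-Linked Inhibitor Series

The source may report more compounds than this note shows. Statements on the series, on what has been measured and on what is new or still open speak of the compounds shown alone.

Of the compounds shown here, two have been measured in an assay on isolated protein for inhibition of Dihydrofolate reductase (Mus musculus); a lower number here means a less potent compound, a higher number a more potent compound, by a factor of ten per unit of this negative logarithm. Compound 1 `CC1(C)N=C(N)N=C(N)N1c1ccc(OCCCNC(=O)c2ccc(S(=O)(=O)F)cc2)c(Cl)c1` gives 7.34 in this assay. Compound 2 `CC1(C)N=C(N)N=C(N)N1c1ccc(OCCCNC(=O)Nc2cccc(S(=O)(=O)F)c2)cc1` gives 7.32 in this assay, a value that lies within the usual scatter of the number for compound 1, so the two cannot be told apart on these data.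

Compound 3 `CC1(C)N=C(N)N=C(N)N1c1ccc(OCCCNC(=O)Nc2cccc(S(=O)(=O)F)c2)c(Cl)c1` differs from compound 2 in one place: chloro in place of hydrogen on an aromatic carbon. No measured pair in this set isolates the effect of this change, so its size is not known from the numbers shown. Compound 1 carries the same chloro group next to its own linker and its value in this assay is indistinguishable from that of compound 2, which suggests that the change may move the number little.

The step expected from compound 2 to compound 3 in this assay is a number 0.13 log units higher from compound 2 to compound 3 (within the scatter), small and not clearly beyond the scatter. Compound 3 is therefore estimated at 7.45 in this assay, with a plausible range from 7 to 7.9.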

Compound 3, logarithm of the reciprocal of the active concentration, log(1/C): 7.28
Compound 3: the middle estimate sits 0.17 log units above what was measured, and the stated range covers the measured number.
By their numbers in this assay, from the lowest: compounds 3, 2 and 1 (each within the scatter of the next).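

In this assay, among these compounds, chloro in place of hydrogen on an aromatic carbon gives a number 0.04 log units lower from compound 2 to compound 3 (within the scatter) and so, for the first time, puts a direct number on this change, which leaves compound 3 and compound 2 indistinguishable at this position. With the chloro group present in both compounds, (3-(fluorosulfonyl)phenyl)amino in place of 4-(fluorosulfonyl)phenyl on a carbonyl carbon gives a number 0.06 log units lower from compound 1 to compound 3 (within the scatter) and is likewise too small to read as a real change. Nothing available here accounts for either result.

From the compounds shown here alone, whether a bromo, methyl or methoxy group on the same aromatic carbon would move the number beyond the scatter remains open. Going by these compounds, it is also open whether chloro would stay as silent with a longer chain joining the shared core to the fluorosulfonyl-bearing ring.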